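The source may report more compounds than this note shows. Statements on the series, on what has been measured and on what is new or still open speak of the compounds shown alone.

In a physicochemical assay for lipophilicity, using the shake flask method, in phosphate buffer, measured as octanol-water partition, with a stated time of 5 h (on this read-out higher numbers stand for higher lipophilicity and lower numbers for lower lipophilicity), compound 2 `COc1cc(/C=C/C(=O)c2ccc(NC(=O)CN3CCN(c4cc5c(cc4F)c(=O)c(C(=O)O)cn5C4CC4)CC3)cc2)cc(OC)c1OC` holds the higher of the two numbers recorded so far, giving 0.753. Its nearest neighbour is compound 1 `O=C(CN1CCN(c2cc3c(cc2F)c(=O)c(C(=O)O)cn3C2CC2)CC1)Nc1ccc(C(=O)/C=C/c2ccc(Cl)cc2)cc1`, which in this assay gives 0.471; the step of a number 0.28 log units higher from compound 1 to compound 2 (within the scatter) is within the scatter, so the two compounds cannot be told apart on this read-out.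

Compound 3 `Cc1ccc(/C=C/C(=O)c2ccc(NC(=O)CN3CCN(c4cc5c(cc4F)c(=O)c(C(=O)O)cn5C4CC4)CC3)cc2)c(C)c1` is not yet measured. It differs from compound 2 in one place: 2,4-dimethylphenyl in place of 3,4,5-trimethoxyphenyl on a double-bonded chain carbon bound to a double-bonded chain carbon.

Going by the values given here, only one measured step touches the same place, the one from compound 1 to compound 2, where 3,4,5-trimethoxyphenyl replaced 4-chlorophenyl, and that step, a number 0.28 log units higher from compound 1 to compound 2 (within the scatter), stayed within the scatter. The data therefore give no sign that exchanging one aryl group for another at this position moves this assay by much. For compound 3 a step of a number 0.10 log units higher from compound 2 to compound 3 (within the scatter) is expected, no larger than the usual scatter and possibly not distinguishable from none. The estimate for compound 3 in this assay is 0.85, with a range from 0.35 to 1.35.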

Compound 3, partition coefficient: 1.47
Compound 3: the middle estimate sits 0.62 log units below what was measured; the whole stated range lies below it.
By their numbers in this assay, from the lowest: compounds 1 and 2 (each within the scatter of the next); then compound 3.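

In this assay the aryl group on a double-bonded chain carbon bound to a double-bonded chain carbon can clearly move the read-out: 2,4-dimethylphenyl in place of 3,4,5-trimethoxyphenyl gives a number 0.72 log units higher from compound 2 to compound 3 (beyond the scatter) and 2,4-dimethylphenyl in place of 4-chlorophenyl gives a number 1.00 log units higher from compound 1 to compound 3 (beyond the scatter) in this series. Going by these compounds alone, the only earlier step at this place, a number 0.28 log units higher from compound 1 to compound 2 (within the scatter) for 3,4,5-trimethoxyphenyl in place of 4-chlorophenyl, could not separate its two compounds, so the position now appears responsive to at least this one exchange, with compound 3 set apart from both compound 1 and compound 2. Nothing in the data accounts for this difference.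

With only three aryl groups on one shared core, the compounds shown cannot tell whether the two methyl groups act together or whether one alone would give a step of this size. Nor do they show how this assay would respond to a plain phenyl ring, or to a phenyl ring carrying an amine or a carboxylic acid, at this place.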